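Fluorophenyl versus ester at the stilbene terminus

This account rests on a few compounds, and the source may have more. Where it says the series, first, only, none or still open, it means among the compounds named here.

Measured compounds in an assay on isolated protein with Bile acid receptor (Homo sapiens) as the target; a lower number here means that less compound is needed, a higher number that more compound is needed for the effect:
- compound 1 `COC(=O)/C=C/c1cccc(N(Cc2ccc(/C=C/c3ccccc3F)cc2)C(=O)NC(C)C)c1`: 431 nM
- compound 2 `COC(=O)/C=C/c1cccc(N(Cc2ccc(/C=C/c3cccc(F)c3)cc2)C(=O)C2CCCCC2)c1`: 86 nM
- compound 3 `COC(=O)/C=C/c1cccc(N(Cc2ccc(/C=C/C(=O)OC(C)(C)C)cc2)C(=O)NC(C)C)c1`: 212 nM

Compound 3 stands second highest of the three numbers in this assay. Its nearest neighbour on the scale is compound 1, whose number is higher, beyond the scatter; compound 2 lies furthest away, with a lower number, again beyond the scatter.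

The next compound is compound 4 `COC(=O)/C=C/c1cccc(N(Cc2ccc(/C=C/c3cccc(F)c3)cc2)C(=O)NC(C)C)c1`. The change from compound 3 to compound 4 is 3-fluorophenyl in place of tert-butoxycarbonyl on a double-bonded chain carbon bound to a double-bonded chain carbon. The urea part of the core is kept.

Within the data shown here, one measured step bears on this change, in the opposite direction: a 2.0-fold lower number from compound 1 to compound 3 (0.31 log units; beyond the scatter). Read backwards, putting an aryl group back in place of the ester would be expected to raise the number by a similar modest amount. Whether a fluorine at the 3-position behaves like one at the 2-position is not known from these compounds; compound 2 carries the same 3-fluorophenyl group with a different acyl part and gives a lower number than compound 3, but that pair differs in two places, so it shows only the two values.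

Taking the reverse of that step as the guide, compound 4 is expected in this assay at 320 nM (range 110 nM to 900 nM), an estimated step of a 1.5-fold higher number from compound 3 to compound 4 (0.18 log units; within the scatter).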

Compound 4, half-maximal effective concentration: 467 nM
For compound 4 the middle estimate is 1.5-fold (0.16 log units) below the measured one, within the range that was stated.
By their numbers in this assay, from the lowest: compound 2; then compound 3; then compounds 1 and 4 (each within the scatter of the next).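

In this assay putting 3-fluorophenyl in place of tert-butoxycarbonyl gives a 2.2-fold higher number from compound 3 to compound 4 (0.34 log units; beyond the scatter) and so adds a second aryl group to the comparison with the ester, which holds the lower number in both urea pairs. Moving the fluorine from 2-fluorophenyl to 3-fluorophenyl gives a 1.1-fold higher number from compound 1 to compound 4 (0.03 log units; within the scatter) and so shows no readable difference between these two aryl groups on the urea series. With 3-fluorophenyl held constant, isopropylamino in place of cyclohexyl on the carbonyl carbon gives a 5.4-fold higher number from compound 2 to compound 4 (0.73 log units; beyond the scatter) and this is a larger step than the one between ester and aryl, so the group on the carbonyl carbon moves the number further here than the group at the stilbene terminus does; no measurement on hand accounts for either step.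

The compounds shown leave open whether the ester keeps its lower number when cyclohexyl replaces isopropylamino on the carbonyl carbon, as only aryl groups accompany cyclohexyl here. They also leave open how a free carboxylic acid or an unsubstituted phenyl would read at this position, and whether a longer chain on the urea would move the number as far as cyclohexyl does.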